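This account rests on a few compounds, and the source may have more. Where it says the series, first, only, none or still open, it means among the compounds named here.

Going by the values given here, in a functional assay on CCRF-CEM cells (Homo sapiens) for antiproliferative activity, read by cell counting, with a stated time of 72 h (a higher number here means a weaker inhibitor, a lower number a stronger inhibitor), compound 2 `C#C[C@@]1(O)[C@@H](CO)O[C@@H](n2cc(-c3ccco3)c3c(N)ncnc32)[C@@H]1O` gives 17000 nM, the higher of the two numbers so far, while compound 1 `C#C[C@@]1(O)[C@@H](CO)O[C@@H](n2cc(F)c3c(N)ncnc32)[C@@H]1O` gives 160 nM. Compound 3 `C#Cc1cn([C@@H]2O[C@H](CO)[C@](O)(C#C)[C@H]2O)c2ncnc(N)c12` has ethynyl in place of furan-2-yl on an aromatic carbon of the shared core: ethynyl in place of furan-2-yl on an aromatic carbon. Among the compounds with values here, one measured step bears on this place, the large 110-fold higher number from compound 1 to compound 2 (2.03 log units; beyond the scatter), with furan-2-yl in place of fluoro. Ethynyl is the smaller group, so a large drop in this assay is expected, though a single step is thin evidence. The expected change is a 28-fold lower number from compound 2 to compound 3 (1.45 log units; beyond the scatter). For compound 3 the estimated value is 600 nM, within a range of 80 nM to 5000 nM.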

Compound 3, half-maximal inhibitory concentration: 63000 nM
For compound 3 the middle estimate is 110-fold (2.02 log units) below the measured one; the whole stated range lies below it.
By their numbers in this assay, from the lowest: compound 1; then compound 2; then compound 3.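

Heavy-atom count does not set the order at this position: ethynyl is smaller than furan-2-yl, yet this assay shows a 3.7-fold higher number from compound 2 to compound 3 (0.57 log units; beyond the scatter) for this swap. Fluoro stays well ahead of ethynyl too, with a 390-fold higher number from compound 1 to compound 3 (2.60 log units; beyond the scatter) on the same carbon. Nothing measured here explains this order. Going by these compounds alone, with only three groups compared at this place, it remains open whether chloro, methyl or an amine would fall nearer fluoro or nearer the other two. From the compounds shown here alone, a longer chain ending in ethynyl is equally open.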